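The source may report more compounds than this note shows. Statements on the series, on what has been measured and on what is new or still open speak of the compounds shown alone.

Compound 1, `Nc1sc2c(c1C(=O)c1ccc(Cl)c3ccccc13)CCC2`: 0%
Compound 2, `Nc1sc2c(c1C(=O)c1ccc(Br)c3ccccc13)CCC2`: 22%
Compound 3, `Nc1sc2c(c1C(=O)c1ccc(Cl)c3ccccc13)CCCC2`: 30.5%

All three were tested in an assay on isolated protein with adenosine receptor A3 (Homo sapiens) as the target, tested at 10 uM; a higher number here means more inhibition at the concentration tested (going by the name of the read-out), a lower number less inhibition. Compound 1 and compound 2 share one core; compound 3 has a different core, and the difference between the two cores is not broken down here. Compound 1 and compound 2 differ only by one change, (bromo in place of chloro on an aromatic carbon), and that change made a step of a number 22 percentage points higher from compound 1 to compound 2 (beyond the scatter). Compound 3 stands highest of the three in this assay, though its gap to compound 2 lies within the usual scatter, so no order between those two can be read.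

Compound 4, `Nc1sc2c(c1C(=O)c1ccc(Br)c3ccccc13)CCCC2`, has not yet been measured. It is compound 3 with the same change, (bromo in place of chloro on an aromatic carbon), made on the same place as before. Within the data shown here, the only guide to what this change does is the single step from compound 1 to compound 2. On that basis, a step of about a number 17.5 percentage points higher from compound 3 to compound 4 (beyond the scatter) is expected from compound 3 to compound 4, because a number 22 percentage points higher from compound 1 to compound 2 (beyond the scatter) points upward. Compound 4 is therefore estimated at 48%, with a plausible range from 28% to 68%.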

Compound 4, a percentage reported as inhibition, at one concentration (the size of the read-out at that concentration, not a potency): 48.5%
Compound 4: the middle estimate sits 0.5 percentage points below what was measured, and the stated range covers the measured number.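

In this assay, putting bromo in place of chloro on the second core gave a step of a number 18 percentage points higher from compound 3 to compound 4 (beyond the scatter). Set beside the earlier step, the change carried over from one core to the other, with no difference in size that can be told apart: the same change on two cores in this assay, a number 22 percentage points higher (beyond the scatter) from compound 1 to compound 2 and a number 18 percentage points higher (beyond the scatter) from compound 3 to compound 4, 4 percentage points apart, within the scatter of two such steps. This shows that the gain held on these two cores, but only for this one aromatic carbon and for inhibition read at a single concentration, which is not a potency, so it neither predicts the step on any further core nor explains why bromo gives it.

The compounds shown leave open what a different group on the same aromatic carbon, such as fluoro, iodo, methyl or methoxy, would do in this assay. They also leave open whether the step would survive a change elsewhere in the molecule, for example an amide in place of the amine that all four compounds share.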